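Ester variation on a flavanolignan scaffold: compound 4 expected

The compounds below may be only part of what the source reports. "The series", "measured", "known", "first", "only" and "open" are said of these compounds alone.

Measured compounds: compound 1 `COc1ccc(C(=O)OCC2Oc3ccc([C@H]4Oc5cc(O)cc(O)c5C(=O)[C@@H]4O)cc3OC2c2ccc(O)c(OC)c2)cc1` gives 73300 nM in a functional assay, read by spectrophotometry, with a stated time of 30 min; on this read-out higher numbers stand for an effect only at larger amounts of compound and lower numbers for an effect already at smaller amounts; compound 2 `COc1cc(C2Oc3cc([C@H]4Oc5cc(O)cc(O)c5C(=O)[C@@H]4O)ccc3OC2COC(=O)c2ccc(N)cc2)ccc1O` gives 128000 nM in this assay; compound 3 `CCOC(=O)CC(=O)OCC1Oc2ccc([C@H]3Oc4cc(O)cc(O)c4C(=O)[C@@H]3O)cc2OC1c1ccc(O)c(OC)c1` gives 101000 nM in this assay.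

Compound 3 stands second highest of the three, with all three values within the scatter of one another. Compound 4 `COc1cc(C2Oc3cc([C@H]4Oc5cc(O)cc(O)c5C(=O)[C@@H]4O)ccc3OC2COC(=O)c2ccc(OC)c(OC)c2)ccc1O` differs from compound 3 by 3,4-dimethoxyphenyl in place of (ethoxycarbonyl)methyl on a carbonyl carbon. Among the compounds with values here, the steps that bear on this change are a 1.4-fold higher number from compound 1 to compound 3 (0.14 log units; within the scatter) and a 1.3-fold lower number from compound 2 to compound 3 (0.10 log units; within the scatter), both exchanging an aryl ester for the (ethoxycarbonyl)methyl ester without any movement beyond the scatter. Compound 4 is therefore expected to show no step beyond the scatter in this assay, with a 1.2-fold lower number from compound 3 to compound 4 (0.07 log units; within the scatter) as the estimated change. Compound 4 is expected to give 85000 nM in this assay, with a range from 35000 nM to 200000 nM.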

Compound 4, half-maximal effective concentration: 77000 nM
Compound 4: the middle estimate sits 1.1-fold (0.04 log units) above what was measured, within the range that was stated.
By their numbers in this assay, from the lowest: compounds 1, 4, 3 and 2 (each within the scatter of the next).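

Methoxy in place of hydrogen on an aromatic carbon of the ester leaves the number in this assay within the scatter, with a 1.1-fold higher number from compound 1 to compound 4 (0.02 log units; within the scatter) as the whole step. The 3,4-dimethoxyphenyl group also stays within the scatter of the other two esters, with a 1.3-fold lower number from compound 3 to compound 4 (0.12 log units; within the scatter) and a 1.7-fold lower number from compound 2 to compound 4 (0.22 log units; within the scatter) on the same carbonyl carbon, so none of the four ester groups shown is set apart from another. Nothing measured here offers an explanation for these numbers. From the compounds shown here alone, whether a carboxylic acid, an aliphatic amine or a longer alkyl chain on this carbonyl carbon would move the number beyond the scatter remains open.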